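This account rests on a few compounds, and the source may have more. Where it says the series, first, only, none or still open, it means among the compounds named here.

Measured so far, all in a functional assay on A 172 cells (Homo sapiens) for cytotoxicity, read by colorimetric assay and MTT assay (on this read-out higher numbers stand for weaker inhibition and lower numbers for stronger inhibition), as the read-out:

- compound 1 `COc1ccc2cc(-c3ccccc3)c(O)nc2c1` gives 10000 nM
- compound 2 `CCOC(=O)Cn1c(=O)c(-c2ccc(OC)cc2)cc2c(OC)cc(OC)cc21` gives 10000 nM
- compound 3 `CCN(CC)C(=O)Cn1c(=O)c(-c2ccc(OC)cc2)cc2c(OC)cc(OC)cc21` gives 10000 nM

Compound 3 stands level with compound 1 and compound 2 at the digits shown. Next is compound 4 `COc1ccc(-c2cc3c(OC)cc(OC)cc3n(CC#N)c2=O)cc1`, with this difference from compound 3 : cyano in place of diethylcarbamoyl on a saturated chain carbon bound to an aromatic nitrogen. In short, cyano in place of diethylcarbamoyl on a saturated chain carbon bound to an aromatic nitrogen. Within the data shown here, the only measured step on this side chain shows no change at the digits printed from compound 2 to compound 3 (within the scatter), though no measured compound carries cyano. No step beyond the scatter is therefore expected in this assay. The estimated step is no change at the digits printed from compound 3 to compound 4 (within the scatter), in neither direction. For compound 4 the expected value is 10000 nM, with an estimated range from 4000 nM to 15000 nM.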

Compound 4, half-maximal inhibitory concentration: 10000 nM
The estimate for compound 4 equals the measured number at the digits printed; measured number inside the range.
By their numbers in this assay, from the lowest: compounds 1, 2, 3 and 4 (each within the scatter of the next).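

In this assay, cyano in place of diethylcarbamoyl on a saturated chain carbon bound to an aromatic nitrogen gives no change at the digits printed from compound 3 to compound 4 (within the scatter) and cyano in place of ethoxycarbonyl at that place gives no change at the digits printed from compound 2 to compound 4 (within the scatter) in the same read-out. Going from the 7 heavy atoms of diethylcarbamoyl to the 2 of cyano therefore leaves the number level, and the nitrile, ester and amide ends of this side chain are not separated. Nothing available gives a reason for this flat result.

As far as these compounds go, whether any group at this place can move the value stays open, since all the compounds shown sit level. A carboxylic acid or a primary amine at the end of this chain might or might not separate from them.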